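Shortening the Nitrooxy Ester Chain: Compound 1 to Compound 3

A few compounds are considered here, and "the series" means these few. Any claim that something is new, unique, unknown or untested is made for them only; others in the source may bear on it.

Among the compounds with values here, compound 1 `CC1=C(C(=O)OCCCCO[N+](=O)[O-])C(c2cccc3nonc23)C([N+](=O)[O-])=C(C)C1` was tested in a functional assay (ileum) for antagonist activity, with Cavia porcellus as the target (on this read-out lower numbers stand for stronger inhibition and higher numbers for weaker inhibition), and gives 878 nM, the higher of the two numbers measured so far, though compound 2 `CC1=C(C(=O)O[C@@H](C)CO[N+](=O)[O-])[C@@H](c2cccc3nonc23)C([N+](=O)[O-])=C(C)C1` gives 577 nM, which lies within the usual scatter of that result. Compound 3 `CC1=C(C(=O)OCC(C)O[N+](=O)[O-])C(c2cccc3nonc23)C([N+](=O)[O-])=C(C)C1` has not yet been measured. It differs from compound 1 in one place: 1-(nitrooxy)ethyl in place of 3-(nitrooxy)propyl on a saturated chain carbon bound to an oxygen next to a carbonyl group. Within the data shown here, no measured step of this kind is available, so the size of the change can only be estimated. For compound 3 the expected step is a 1.3-fold lower number from compound 1 to compound 3 (0.10 log units; within the scatter), staying within the scatter, because compound 2 gives 577 nM. Compound 3 is estimated at 700 nM, in a range from 300 nM to 1600 nM.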

Compound 3, half-maximal inhibitory concentration: 1700 nM
For compound 3 the middle estimate is 2.4-fold (0.39 log units) below the measured one; the measured number lies above the stated range.
By their numbers in this assay, from the lowest: compounds 2, 1 and 3 (each within the scatter of the next, the first and the last beyond it).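

In this assay putting 1-(nitrooxy)ethyl in place of 3-(nitrooxy)propyl gives a 1.9-fold higher number from compound 1 to compound 3 (0.29 log units; within the scatter) and so stays within the scatter. Within the data shown here, this is the first step read at this place, a saturated chain carbon bound to an oxygen next to a carbonyl group, and this change does not clearly move the number beyond repeat-measurement noise. No measured information is at hand to explain the result.

Going by these compounds, whether a longer chain or a carboxylic acid at this place would give a step beyond the scatter remains open.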